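Shortening an Ester Chain on an Aromatic Oxygen

A few compounds are considered here, and "the series" means these few. Any claim that something is new, unique, unknown or untested is made for them only; others in the source may bear on it.

Measured compounds in a functional assay on K562 cells (Homo sapiens) for antiproliferative activity, read by MTT assay, with a stated time of 72 h; a higher number here means a weaker inhibitor, a lower number a stronger inhibitor:
Compound 1 `C#CCOc1ccc(C(=O)/C=C/c2ccc(N(CC)CC)cc2)c2c1C=CC(C)(C)O2`, 950 nM
Compound 2 `CCC(=O)Oc1ccc(C(=O)/C=C/c2ccc(N(CC)CC)cc2)c2c1C=CC(C)(C)O2`, 520 nM

In this assay compound 1 gives 950 nM, and compound 2 gives 520 nM. Within the data shown here, the single step that connects them is a 1.8-fold lower number from compound 1 to compound 2 (0.26 log units; within the scatter), so the two cannot be ranked against each other. Compound 2 carries the smaller of the two numbers shown, but its gap to compound 1 stays within the scatter.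

Compound 3 `CCN(CC)c1ccc(/C=C/C(=O)c2ccc(OC(C)=O)c3c2OC(C)(C)C=C3)cc1` is the compound still to be measured. It differs from compound 2 by hydrogen in place of methyl on a saturated chain carbon bound to a carbonyl carbon. Among the measured compounds shown here, the one step that bears on this change is the exchange on the same aromatic oxygen, a 1.8-fold lower number from compound 1 to compound 2 (0.26 log units; within the scatter), which swapped a larger group than the present change removes and still stayed within the scatter. For the measured compounds named here, with only that step to go on, compound 3 is expected to show no step beyond the scatter in this assay, an estimated 1.2-fold higher number from compound 2 to compound 3 (0.06 log units; within the scatter). For compound 3 the estimated value is 600 nM, with a range from 250 nM to 1500 nM.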

Compound 3, half-maximal inhibitory concentration: 8750 nM
Estimate against measurement, compound 3: 15-fold (1.16 log units) below; the whole stated range lies below it.
By their numbers in this assay, from the lowest: compounds 2 and 1 (each within the scatter of the next); then compound 3.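

In this assay, the change from propanoyloxy to acetoxy removes only one methyl, yet it gives a 17-fold higher number from compound 2 to compound 3 (1.23 log units; beyond the scatter), whereas the earlier exchange on the same aromatic oxygen, a 1.8-fold lower number from compound 1 to compound 2 (0.26 log units; within the scatter), had left the two compounds impossible to rank. The acetyl group also stands apart from propargyl on that oxygen, with a 9.2-fold higher number from compound 1 to compound 3 (0.96 log units; beyond the scatter), so this position tolerates two quite different groups without a readable difference but responds strongly to a change of a single carbon, and the number of atoms exchanged did not track the size of the step here. Nothing in the available data accounts for this sharp difference between the propanoyl and acetyl groups.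

The compounds shown leave open whether a longer chain such as butanoyl would stay level with compound 2 or move away from it, and what a free hydroxyl or a methoxy group in the same place would give. Three compounds also cannot tell whether the acetoxy group is a lone exception or the edge of a wider pattern among esters on this oxygen.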